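The source may hold more compounds than are shown below. What is called first, only, known or untested is meant among the compounds shown, and "the series" means these compounds.

In a functional assay on Bel-7402 cells (Homo sapiens) for inhibition, read by MTT assay, with a stated time of 24 h, tested at 100 ug/mL (on this read-out higher numbers stand for more inhibition of growth at the one concentration tested and lower numbers for less inhibition of growth), compound 2 (`O=C(CCCCC(S)CCS)Nc1ccccn1`) gives 3.62%. Compound 1 (`O=C(CCCCC1CCSS1)Nc1ccc(Cl)cn1`) gives 48.5% in the same test. For the measured compounds named here, compound 2 holds the lower of the two numbers so far, and the gap between the two compounds lies beyond the scatter. Compound 3 (`O=C(CCCCC(S)CCS)Nc1ccc(Cl)cn1`) has a single change (chloro in place of hydrogen on an aromatic carbon) that puts chloro in place of hydrogen on an aromatic carbon. Going by the values given here, no measured pair shows this change alone, so only a modest rise in this assay is expected, of a size near the scatter. The estimated move is a number 10.4 percentage points higher from compound 2 to compound 3 (beyond the scatter) on this reasoning. For compound 3 the expected value is 14% within a range from 2% to 35% as an estimate.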

Compound 3, percent growth inhibition at one concentration: 50.7%
Compound 3: the middle estimate sits 36.7 percentage points below what was measured, outside the stated range (above it).
By their numbers in this assay, from the lowest: compound 2; then compounds 1 and 3 (each within the scatter of the next).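

In this assay, chloro in place of hydrogen, two atoms from the ring nitrogen and para to a large group, gives a number 47.1 percentage points higher from compound 2 to compound 3 (beyond the scatter), so this single atom on the aromatic ring makes a large difference. The side chain's form shows no such difference once chloro is present: the open chain in place of the five-membered ring gives a number 2.2 percentage points higher from compound 1 to compound 3 (within the scatter). Nothing measured here explains the chloro effect. As far as these compounds go, whether a fluoro or a methoxy group at this position would match chloro remains open.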